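Removing the propyl group from compound 3

A few compounds are considered here, and "the series" means these few. Any claim that something is new, unique, unknown or untested is made for them only; others in the source may bear on it.

In a functional assay on HL-60 cells (Homo sapiens) for antiproliferative activity, read by MTT assay (a higher number here means a weaker inhibitor, a lower number a stronger inhibitor), compound 3 `CCC[C@@H]1O[C@H](COCc2ccccc2)[C@@H](OCc2ccccc2)[C@H](OCc2ccccc2)[C@H]1O` gives 11700 nM, and compound 1 `C=C[C@@H]1O[C@H](COCc2ccccc2)[C@@H](OCc2ccccc2)[C@H](OCc2ccccc2)[C@H]1O` gives 11800 nM. Compound 2 `O[C@@H]1[C@@H](OCc2ccccc2)[C@H](OCc2ccccc2)[C@@H](COCc2ccccc2)O[C@H]1CC1CC1` is reported as "not active" (no number reported), with no number. Compound 4 `O[C@H]1CO[C@H](COCc2ccccc2)[C@@H](OCc2ccccc2)[C@@H]1OCc1ccccc1` is the next case: hydrogen in place of propyl on a saturated ring carbon, so hydrogen stands in place of propyl on a saturated ring carbon. Among the measured compounds shown here, the one measured step, a 1.0-fold lower number from compound 1 to compound 3 (0.00 log units; within the scatter), swaps vinyl for propyl at this carbon and stays within the scatter. It does not show what losing the group altogether does, so the forecast is uncertain. A modest move towards weaker inhibition is expected, an estimated 1.7-fold higher number from compound 3 to compound 4 (0.23 log units; within the scatter). For compound 4 the expected value is 20000 nM, with an estimated range from 8000 nM to 60000 nM.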

Compound 4, half-maximal inhibitory concentration: "not active" (no number reported)
No number was reported for compound 4; no gap can be computed for the estimate.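

Compound 4 is reported as "not active" with no number, so the step from compound 3 to compound 4 cannot be read. Nothing measured here explains this result. The compounds shown leave open how far compound 4 lies from compound 3.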